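A small change on one arm of compound 3

The source may hold more compounds than are shown below. What is called first, only, known or untested is meant among the compounds shown, and "the series" means these compounds.

Of the compounds shown here, three built on a shared core have been tested in a functional assay on MDA-MB-231 cells (Homo sapiens) for antiproliferative activity, read by MTT assay, with a stated time of 24 h; on this read-out higher numbers stand for weaker inhibition and lower numbers for stronger inhibition. Compound 3 `COc1cc(-c2cc(/C=C/C(=O)c3ccccc3)nc3cc(-c4ccccc4)nn23)cc(OC)c1OC` gives 15800 nM, which stands second highest of the three numbers. Its nearest neighbour is compound 1 `COc1ccc(/C=C/C(=O)c2cc(-c3cc(OC)c(OC)c(OC)c3)n3nc(-c4ccccc4)cc3n2)cc1OC`, which gives 14200 nM; the two numbers lie within the scatter of each other. The furthest is compound 2 `COc1cc(-c2cc(/C=C/C(=O)c3ccc(C)cc3)nc3cc(-c4ccccc4)nn23)cc(OC)c1OC`, which gives 23900 nM, also within the scatter of compound 3.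

Within the data shown here, only one step between the measured compounds changes a single place: a 1.5-fold lower number from compound 2 to compound 3 (0.18 log units; within the scatter). That change sits on the same part of the molecule that differs between compound 3 and compound 4, yet it moved the number no further than repeated measurements would.

Compound 4 `COc1ccc(/C=C/C(=O)c2cc(-c3cc(OC)c(OC)c(OC)c3)n3nc(-c4ccccc4)cc3n2)cc1` has not yet been measured. It differs from compound 3 in one place: (2-(4-methoxyphenyl)ethenyl)carbonyl in place of 2-benzoylethenyl on an aromatic carbon. Among the measured compounds shown here, no measured step exchanges the whole of this group, so the expectation rests on the measured values alone, which all lie in a narrow band from compound 1 to compound 2. In this assay, compound 4 is therefore expected to give 14500 nM, with a likely range from 7000 nM to 30000 nM. That estimate means a step of a 1.1-fold lower number from compound 3 to compound 4 (0.04 log units; within the scatter), which is expected to stay within the usual scatter.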

Compound 4, half-maximal inhibitory concentration: 16500 nM
For compound 4 the middle estimate is 1.1-fold (0.06 log units) below the measured one; low and high end bracket the measured number.
By their numbers in this assay, from the lowest: compounds 1, 3, 4 and 2 (each within the scatter of the next).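

In this assay, (2-(4-methoxyphenyl)ethenyl)carbonyl in place of 2-benzoylethenyl gives a 1.0-fold higher number from compound 3 to compound 4 (0.02 log units; within the scatter) and so leaves the number within the scatter, even though this exchange rebuilds the whole arm rather than one small substituent. Among these compounds, the same holds against the arm carrying a methyl group, with a 1.4-fold lower number from compound 2 to compound 4 (0.16 log units; within the scatter) for the exchange with 2-((4-methylphenyl)carbonyl)ethenyl, and a 1.2-fold higher number from compound 1 to compound 4 (0.07 log units; within the scatter) adds a first single-group change on the arm of compound 1, hydrogen in place of methoxy, which also stays within the scatter. All the steps at this position now read the same way, so neither the way the arm is put together nor these small ring substituents separates the four compounds in this assay, and nothing available offers a reason for that.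

From the compounds shown here alone, the arm's outer ring carries only hydrogen, methyl or methoxy here, so it remains open whether an amine or a carboxylic acid on that ring would move the number beyond the scatter. Also open is whether a longer chain in place of the ethenyl link would do so, since every arm shown keeps that same short link.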